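The source may hold more compounds than are shown below. What is called first, only, known or untested is meant among the compounds shown, and "the series" means these compounds.

Measured so far in a functional assay on SF-268 cells (Homo sapiens) for inhibition, read by sulforhodamine B assay, with a stated time of 48 h; a lower number here means a stronger inhibitor of growth, a higher number a weaker inhibitor of growth:
compound 1 `COc1ccc(-c2cc(/C=C/C(=O)c3ccc(N)cc3)[nH]n2)cc1`, 5310 nM
compound 2 `COc1cc(-c2cc(/C=C/C(=O)c3ccc(N)cc3)[nH]n2)cc(OC)c1OC`, 3930 nM
compound 3 `COc1ccc(C(=O)/C=C/c2cc(-c3cc(OC)c(OC)c(OC)c3)n[nH]2)cc1OC`, 3960 nM

Compound 2 carries the lowest of the three numbers, yet neither gap is beyond the usual scatter: the step of a 1.0-fold higher number from compound 2 to compound 3 (0.00 log units; within the scatter) is flat, and the number for compound 1 is only slightly higher than that for compound 2. Across the three compounds both the aryl on the carbonyl carbon and the methoxy pattern on the aryl attached to the shared core vary without shifting this assay in a way that can be read as real.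

Compound 4 `COc1ccc(-c2cc(/C=C/C(=O)c3ccc(N)cc3)[nH]n2)cc1OC` is the next member. Relative to compound 2 the change is hydrogen in place of methoxy on an aromatic carbon. Going by the values given here, no measured step removes exactly one methoxy from that ring, so a direct precedent is lacking. The nearest indication is the pair of compound 1, with fewer methoxy groups on that ring, and compound 2, whose two values differ only within the scatter. On that basis no step beyond the scatter is expected in this assay; the expected step is a 1.1-fold higher number from compound 2 to compound 4 (0.06 log units; within the scatter). Compound 4 is therefore estimated at 4500 nM in this assay, with a range from 2400 nM to 8500 nM.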

Compound 4, concentration for total growth inhibition: 4400 nM
Beside the measured number, compound 4's estimate is 1.0-fold (0.01 log units) above it; low and high end bracket the measured number.
By their numbers in this assay, from the lowest: compounds 2, 3, 4 and 1 (each within the scatter of the next).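

Going by these compounds alone, compound 4 adds the first single-site methoxy changes on the aryl attached to the shared core. In this assay, hydrogen in place of the methoxy that stands ortho to a methoxy group and meta to a large group gives a 1.1-fold higher number from compound 2 to compound 4 (0.05 log units; within the scatter), while methoxy in place of hydrogen on the same ring gives a 1.2-fold lower number from compound 1 to compound 4 (0.08 log units; within the scatter). With the 4-aminophenyl on the carbonyl carbon held constant, both single changes therefore stay within the scatter, so this ring position shows no readable response to methoxy against hydrogen in this assay, and nothing available accounts for that flat result.

On these data alone, only methoxy and hydrogen have been compared at this position, so it remains open whether a hydroxy group, a fluorine atom, a dimethylamino group or a carboxylic acid there would move the number in this assay beyond the scatter. As far as these compounds go, it is also open whether the same methoxy change would stay as flat with a 4-hydroxyphenyl or a 4-acetamidophenyl in place of the 4-aminophenyl on the carbonyl carbon.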